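Swapping methoxy for chloro on the anilide of compound 3

The source may hold more compounds than are shown below. What is called first, only, known or untested is meant among the compounds shown, and "the series" means these compounds.

Measured so far in a physicochemical assay for solubility, in phosphate buffer, measured as kinetic solubility, with a stated time of 1 h, at pH 7.4; on this read-out lower numbers stand for lower solubility and higher numbers for higher solubility:
- compound 1, `CCOc1ccc2nc(C(F)(F)F)cc(OCC(=O)Nc3cc(C)cc(C)c3)c2c1`, gives < 1000 nM, which is a limit of the assay rather than a number.
- compound 2, `COc1ccc2nc(C)cc(NC(=O)C(=O)Nc3cc(C)cc(C)c3)c2c1`, gives 10000 nM.
- compound 3, `COc1ccc(NC(=O)COc2cc(C)nc3ccc(OC)cc23)cc1`, gives 108000 nM.

Among the two compounds with a number, compound 3 stands highest, and its gap to compound 2 lies beyond the usual scatter of this assay. Compound 1 contributes only a limit and so cannot be placed in that order.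

Compound 4, `COc1ccc2nc(C)cc(OCC(=O)Nc3ccc(Cl)cc3)c2c1`, has not yet been measured. It differs from compound 3 in one place: chloro in place of methoxy on an aromatic carbon. For the measured compounds named here, no measured pair with this same change is available, so the expectation rests on the change alone. A moderate drop in this assay is expected, beyond the scatter, so that the step from compound 3 to compound 4 is estimated at a 3.6-fold lower number from compound 3 to compound 4 (0.56 log units; beyond the scatter). Compound 4 is therefore expected to give about 30000 nM, with a likely range from 8000 nM to 100000 nM.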

Compound 4, solubility: 9000 nM
Compound 4: the middle estimate sits 3.3-fold (0.52 log units) above what was measured; low and high end bracket the measured number.
By their numbers in this assay, from the lowest: compounds 4 and 2 (each within the scatter of the next); then compound 3. At a limit, below all of these: compound 1.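

The change from 4-methoxyphenyl to 4-chlorophenyl gives a 12-fold lower number from compound 3 to compound 4 (1.08 log units; beyond the scatter) in this assay, and this is the only comparison among the compounds shown that differs in one place. For the compounds shown here, it shows that the group on this aromatic carbon, para to a large group, can move the read-out well beyond the scatter even when the rest of the molecule stays the same, which the earlier compounds, differing in several places at once, could not show. Neither compound 3 nor compound 4 sits at a limit, so the whole step can be read as a number: the limit of < 1000 nM in this assay, at which 1 of the 4 values shown sits.

On these data alone, what remains open is how an amine, a carboxylic acid or a plain hydrogen at this same place would read. As far as these compounds go, it is also open whether the same change from methoxy to chloro would give a step of similar size on the core of compound 2.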